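Swapping an aryl ether for a benzyl nitrile

The source may report more compounds than this note shows. Statements on the series, on what has been measured and on what is new or still open speak of the compounds shown alone.

Measured so far, in a physicochemical assay for solubility, with a stated time of 18 h, at pH 7.4; a lower number here means a less soluble compound, a higher number a more soluble compound:
compound 1 `c1ccc(Oc2ccc3c(NCCCNCc4ccco4)ccnc3c2)cc1`; compound 1 gives 14500 nM
compound 2 `COc1cccc(CNCCCNc2ccnc3cc(Oc4ccc(Cl)cc4)ccc23)c1O`; compound 2 gives 14500 nM
compound 3 `COc1ccc(F)cc1CNCCCNc1ccnc2cc(CCC(C)C)ccc12`; compound 3 gives 4200 nM

Compound 2 stands level with compound 1 at the digits shown, and the two together are the highest of the three; compound 3 sits lower, by an amount beyond the usual scatter of this assay. Compound 4 `COc1cccc(CNCCCNc2ccnc3cc(Cc4ccc(C#N)cc4)ccc23)c1O` has not yet been measured. It differs from compound 2 in one place: 4-cyanobenzyl in place of 4-chlorophenoxy on an aromatic carbon. Among the measured compounds shown here, no measured pair that differs in exactly one place is available, so the expectation rests on the spread among the three compounds. The step from compound 2 to compound 4 is expected to be small, a 1.5-fold lower number from compound 2 to compound 4 (0.16 log units; within the scatter), at most a modest drop. Compound 4 is estimated at 10000 nM, within 3000 nM to 30000 nM.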

Compound 4, solubility: 4200 nM
For compound 4 the middle estimate is 2.4-fold (0.38 log units) above the measured one; the range from low to high includes it.
By their numbers in this assay, from the lowest: compounds 3 and 4 (each within the scatter of the next); then compounds 1 and 2 (each within the scatter of the next).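

In this assay this position on the shared core responds to its substituent: 4-cyanobenzyl in place of 4-chlorophenoxy on an aromatic carbon gives a 3.5-fold lower number from compound 2 to compound 4 (0.54 log units; beyond the scatter) and so a modest step beyond the scatter. Among the compounds shown here, this is the first comparison here between two compounds that differ in one place, so the size of a change at this position can be read directly. Nothing available explains the drop.

The swap alters the end group and the link to the core together, leaving open which of the two matters. On these data alone, a 4-cyanophenoxy group on the same carbon would separate them, and how it would compare remains unknown.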